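Adding a fluorine to the triazole-bound phenyl ring

The source may report more compounds than this note shows. Statements on the series, on what has been measured and on what is new or still open speak of the compounds shown alone.

Of the compounds shown here, three sharing one core have been tested in a functional assay on HT-29 cells (Homo sapiens) for cytotoxicity, read by MTT assay, with a stated time of 72 h; on this read-out lower numbers stand for stronger inhibition and higher numbers for weaker inhibition. Compound 1 `COc1cc2c(Oc3ccc(NC(=O)c4cn(-c5ccccc5F)nn4)cc3F)ccnc2cc1OCCCN1CCCCC1` gives 290 nM. Among the measured compounds shown here, compound 2 `COc1cc2c(Oc3ccc(NC(=O)c4cn(-c5ccccc5F)nn4)cc3F)ccnc2cc1OCCCN1CCC(C)CC1` gives 210 nM; the only measured single-place step, a 1.4-fold lower number from compound 1 to compound 2 (0.14 log units; within the scatter), lies at the saturated amine ring and stays within the scatter. Compound 3 `COc1cc2c(Oc3ccc(NC(=O)c4cn(-c5ccccc5)nn4)cc3F)ccnc2cc1OCCCN1CCN(C)CC1` gives 180 nM, and all three values sit within the scatter of one another, so none can be called more or less potent than the others.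

Compound 4 `COc1cc2c(Oc3ccc(NC(=O)c4cn(-c5ccccc5F)nn4)cc3F)ccnc2cc1OCCCN1CCN(C)CC1` differs from compound 3 by one change: fluoro in place of hydrogen on an aromatic carbon. For the measured compounds named here, no measured step isolates this change. Compounds 1 and 2 carry the same fluoro-bearing ring as compound 4, yet they also differ from compound 3 at the amine ring, so their values can only show that both arrangements give similar numbers in this assay. With nothing pointing to a shift, compound 4 is expected to land close to compound 3, a step of a 1.1-fold higher number from compound 3 to compound 4 (0.05 log units; within the scatter). The estimate for compound 4 in this assay is 200 nM, with a range from 100 nM to 400 nM.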

Compound 4, half-maximal inhibitory concentration: 300 nM
Compound 4: middle estimate off by 1.5-fold (0.18 log units), on the low side, and the stated range covers the measured number.
By their numbers in this assay, from the lowest: compounds 3, 2, 1 and 4 (each within the scatter of the next).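

Fluoro in place of hydrogen on the phenyl ring, ortho to a large group, can now be read on its own in this assay: a 1.7-fold higher number from compound 3 to compound 4 (0.22 log units; within the scatter), so phenyl and 2-fluorophenyl cannot be told apart here. With 2-fluorophenyl held fixed, the amine ring can also be compared: 4-methylpiperazin-1-yl in place of 4-methylpiperidin-1-yl gives a 1.4-fold higher number from compound 2 to compound 4 (0.15 log units; within the scatter), and in place of piperidin-1-yl gives a 1.0-fold higher number from compound 1 to compound 4 (0.01 log units; within the scatter), so these three amine rings cannot be told apart either. No measurement at hand bears on what lies behind these numbers.

On these data alone, it remains open whether a larger group at this place, such as chloro or methoxy, would give a step beyond the scatter. Also open, as far as these compounds go, is whether morpholine as the amine ring, or a shorter chain carrying it, would do so.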